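Cytotoxicity notes: oxazole to methyl-oxadiazole on the lactam

This account rests on a few compounds, and the source may have more. Where it says the series, first, only, none or still open, it means among the compounds named here.

Three compounds of the series have been run in a toxicity assay on HepG2 2.2.15 cells (Homo sapiens) for cytotoxicity, read by CellTiter-Glo; on this read-out lower numbers stand for higher toxicity in this test and higher numbers for lower toxicity in this test. Compound 1 `O=C(Nc1cc(F)c(F)c(F)c1)N1CCCn2ncc(N3CC(c4ccccc4)CC3=O)c2C1` gives only a limit of the test, > 2000 nM, which matches the limit noted as the limit of > 2000 nM in this assay, at which 1 of the 3 values shown sits. Compound 2 `O=C1OC(c2ccc(F)cc2)CN1c1cnn2c1CN(C(=O)Nc1cc(F)c(F)c(F)c1)C(C1CC1)C2` gives 3560 nM in this assay. Compound 3 `O=C1CC(c2cnco2)CN1c1cnn2c1CN(C(=O)Nc1cc(F)c(F)c(F)c1)C(C1CC1)C2` gives 139000 nM in this assay, the highest of the two numbers shown; its gap to compound 2, the nearest number, lies beyond the scatter, so compound 3 is the less toxic of the two on this read-out.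

Compound 4 `Cc1nc(C2CC(=O)N(c3cnn4c3CN(C(=O)Nc3cc(F)c(F)c(F)c3)C(C3CC3)C4)C2)no1` has not yet been measured. It differs from compound 3 by 5-methyl-1,2,4-oxadiazol-3-yl in place of 1,3-oxazol-5-yl on a saturated ring carbon, the same difference cut one bond further out reading 4-(1,3-oxazol-5-yl)-2-oxopyrrolidin-1-yl to 4-(5-methyl-1,2,4-oxadiazol-3-yl)-2-oxopyrrolidin-1-yl. For the measured compounds named here, no measured pair in the set isolates this kind of change, so no measured step can be pointed to.

Given that the shared core and the urea on the trifluorophenyl ring are kept, and only one small aromatic ring on a saturated ring carbon is exchanged for another, the step is expected to be small, a 1.4-fold lower number from compound 3 to compound 4 (0.14 log units; within the scatter), and not clearly beyond the scatter in either direction. Compound 4 is therefore estimated at 100000 nM in this assay, with a range from 30000 nM to 300000 nM.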

Compound 4, half-maximal cytotoxic concentration: > 200000 nM
Compound 4: no number, only a limit (the forecaster's own chance of this, stated with the estimate: 20%); middle value at least 2.0-fold (0.30 log units) away from the limit.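

In this assay compound 4 gives > 200000 nM, which is a limit of the test and not a number. With 5-methyl-1,2,4-oxadiazol-3-yl in place of 1,3-oxazol-5-yl on a saturated ring carbon of the five-membered non-aromatic ring, the step reads an at least 1.4-fold higher number from compound 3 to compound 4 (0.15 log units; that floor lies within the scatter), so this position now has one measured change, and that change shows no sign of a lower number on this read-out, although its floor alone cannot establish a real rise. The step has only a floor, and its upper end cannot be read, because the value for compound 4 stops at a limit: the limit of > 200000 nM in this assay, at which 1 of the 4 values shown sits.

As far as these compounds go, the true size of the step remains open, and a single pair supports no pattern at this position beyond compound 3 and compound 4. Also open, from the compounds shown here alone, is how an amine or a carboxylic acid on the same saturated ring carbon, in place of either five-membered aromatic ring, would read in this assay with the rest of the structure kept.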